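Homologating the azetidine amide of compound 3

The compounds below may be only part of what the source reports. "The series", "measured", "known", "first", "only" and "open" are said of these compounds alone.

Among the three compounds measured in an assay on lysate for inhibition of 6-phosphofructo-2-kinase/fructose-2,6-bisphosphatase 3 (Homo sapiens), with stated times of 0.5 min and 45 min (on this read-out lower numbers stand for stronger inhibition and higher numbers for weaker inhibition), compound 3 `CC(=O)N1CC(NC(=O)c2ccncc2Nc2cc(-c3ccc4ccn(C)c4c3)c3nccnc3c2)C1` gives 97400 nM, the highest number of the set; compound 1 `Cn1cc(NC(=O)c2ccncc2Nc2cc(-c3ccc4ccn(C)c4c3)c3nccnc3c2)cn1` gives 26500 nM and compound 2 `CC(=O)N1CCC(NC(=O)c2ccncc2Nc2cc(-c3ccc4ccn(C)c4c3)c3nccnc3c2)CC1` gives 31300 nM. The steps of a 3.7-fold higher number from compound 1 to compound 3 (0.57 log units; beyond the scatter) and a 3.1-fold higher number from compound 2 to compound 3 (0.49 log units; beyond the scatter) set compound 3 apart from both beyond the scatter, while a 1.2-fold higher number from compound 1 to compound 2 (0.07 log units; within the scatter) stays within it. Compound 4 `CC(=O)N1CC(CNC(=O)c2ccncc2Nc2cc(-c3ccc4ccn(C)c4c3)c3nccnc3c2)C1` differs from compound 3 by (1-acetylazetidin-3-yl)methyl in place of 1-acetylazetidin-3-yl on an amide-type nitrogen. For the measured compounds named here, none of the measured steps involves such an insertion, so they bear on it only indirectly. The expected step is therefore a 1.4-fold lower number from compound 3 to compound 4 (0.14 log units; within the scatter), not beyond the scatter in either direction. Compound 4 is expected to give 70000 nM in this assay, within a range from 25000 nM to 200000 nM.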

Compound 4, half-maximal inhibitory concentration: > 100000 nM
Compound 4: no number, only a limit (the forecaster's own chance of this, stated with the estimate: 25%); middle value at least 1.4-fold (0.15 log units) away from the limit.
By their numbers in this assay, from the lowest: compounds 1 and 2 (each within the scatter of the next); then compound 3. At a limit, above all of these: compound 4.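

In this assay compound 4 gives no number, only the limit > 100000 nM as its reading. Moving from 1-acetylazetidin-3-yl to (1-acetylazetidin-3-yl)methyl on the amide-type nitrogen brings no lower number, yet the size of any loss cannot be read (an at least 1.0-fold higher number from compound 3 to compound 4 (0.01 log units; that floor lies within the scatter)). The new group stands apart from the other two substituents, with floors beyond the scatter (an at least 3.1-fold higher number from compound 2 to compound 4 (0.50 log units; beyond the scatter)) and (an at least 3.7-fold higher number from compound 1 to compound 4 (0.57 log units; beyond the scatter)).

From the compounds shown here alone, whether a free amine in place of the acetyl, or a longer chain on the amide-type nitrogen, would lower the number stays open. So does the actual value behind the limit.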